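The source may report more compounds than this note shows. Statements on the series, on what has been measured and on what is new or still open speak of the compounds shown alone.

Measured in an ADME assay (liver) for metabolic stability, with Liver microsome (Homo sapiens) as the target, read by LC-MS, using microsomes and NADPH, with a stated time of 5 min, at 37 degrees C; on this read-out higher numbers stand for fast clearance and lower numbers for slow clearance:
- Compound 1 `CCn1c([C@@H](C)NS(=O)(=O)c2ccc(Cl)cc2)nc2ccc(OC)cc21`: > 100 mL.min-1.g-1
- Compound 2 `CCn1c([C@@H](C)NS(=O)(=O)c2ccc(Cl)cc2)nc2ccc(C(F)(F)F)cc21`: > 100 mL.min-1.g-1

Compound 2 gives > 100 mL.min-1.g-1, which is a limit of this assay and not a number. The next compound, compound 3 `CCn1c([C@@H](C)NS(=O)(=O)c2ccc(Cl)cc2)nc2ccc(CO)cc21`, is not yet measured. It carries hydroxymethyl in place of trifluoromethyl on an aromatic carbon.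

Among the measured compounds shown here, the only measured step is a step that the two limits leave unreadable from compound 1 to compound 2, so neither a size nor a direction carries over. Compound 1 and compound 2 share (the limit of > 100 mL.min-1.g-1 in this assay, at which 2 of the 2 values shown sit), and that is the basis for expecting compound 3 to stay close to this limit. The expected step is an at least 1.2-fold lower number from compound 2 to compound 3 (0.09 log units; that floor lies within the scatter). For compound 3 the estimated value is 80 mL.min-1.g-1, with an expected range of 30 mL.min-1.g-1 to 200 mL.min-1.g-1.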

Compound 3, intrinsic clearance in microsomes: 84 mL.min-1.g-1
The estimate for compound 3 lay 1.1-fold (0.02 log units) below the measured number, within the range that was stated.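

With hydroxymethyl on this aromatic carbon, compound 3 gives in this assay a real number of 84 mL.min-1.g-1 and not a limit of the assay, the first such number among the compounds shown. Against trifluoromethyl the change gives an at least 1.1-fold lower number from compound 2 to compound 3 (0.07 log units; that floor lies within the scatter) and against methoxy an at least 1.1-fold lower number from compound 1 to compound 3 (0.07 log units; that floor lies within the scatter) as readable steps, each known only as a floor. From the compounds shown here alone, the step between methoxy and trifluoromethyl cannot be read, and the true size of both floors stays open. Going by these compounds, whether an amine, a carboxylic acid or a longer chain at this place gives a number clearly apart from that of compound 3 also stays open.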